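A few compounds are considered here, and "the series" means these few. Any claim that something is new, unique, unknown or untested is made for them only; others in the source may bear on it.

- compound 1 `CC(C)(C)CCOc1cccc(O)c1C(=O)/C=C/c1ccc(O)cc1` gives 3130 nM
- compound 2 `O=C(/C=C/c1ccc(O)cc1)c1c(O)cccc1OCCC1CCCCC1` gives > 30000 nM

In a functional assay on NCI-H23 cells (Homo sapiens) for antiproliferative activity, read by sulforhodamine B assay (on this read-out higher numbers stand for weaker inhibition of growth and lower numbers for stronger inhibition of growth), compound 2 reads > 30000 nM, which is a limit of the assay and not a number. Among the compounds with values here, the one measured step that bears on the next change is an at least 9.5-fold higher number from compound 1 to compound 2 (0.98 log units; beyond the scatter), with cyclohexyl in place of tert-butyl. Compound 3 `CCC(CC)COc1cccc(O)c1C(=O)/C=C/c1ccc(O)cc1` differs from compound 2 as follows: pentan-3-yl in place of cyclohexylmethyl on a saturated chain carbon bound to an oxygen on an aromatic ring. The ring leaves, so compound 3 should fall closer to compound 1, at 3130 nM, than to compound 2. The expected change is an at least 5.0-fold lower number from compound 2 to compound 3 (0.69 log units; beyond the scatter), towards stronger inhibition of growth. For compound 3 the estimated value is 6000 nM, with an expected range from 2000 nM to 20000 nM.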

Compound 3, concentration for 50% growth inhibition: 3210 nM
Compound 3: middle estimate off by 1.9-fold (0.27 log units), on the high side; the measured number falls inside the stated range.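

An open chain without a ring works at this place where the cyclohexyl-bearing chain does not (an at least 9.3-fold lower number from compound 2 to compound 3 (0.97 log units; beyond the scatter)). The branched pentan-3-yl and neopentyl groups read alike (a 1.0-fold higher number from compound 1 to compound 3 (0.01 log units; within the scatter)), so this position accepts more than one branched chain of this kind. Compound 2 stands at a limit of the assay, not at a number: the limit of > 30000 nM in this assay, at which 1 of the 3 values shown sits.

Compound 3 removes the ring and lowers the carbon count at once, so the data do not separate these two changes. As far as these compounds go, how a shorter chain or an amine on the chain would read at this place remains open.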